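The source may hold more compounds than are shown below. What is called first, only, known or untested is meant among the compounds shown, and "the series" means these compounds.

Measured compounds:
compound 1, `CCCCCCCCCCCCS(=O)(=O)/C=C/c1ccc(O)c(O)c1`; in a functional assay, read by fluorescence and spectrophotometry, with a stated time of 1 h (a lower number here means that less compound is needed, a higher number that more compound is needed for the effect), compound 1 gives 8500 nM
compound 2, `O=S(=O)(/C=C/c1ccc(O)c(O)c1)CC1CCCCC1`; in this assay compound 2 gives 7500 nM

Of the two numbers, compound 1 has the higher one, but its nearest neighbour, compound 2, lies within the scatter of it, so the two compounds cannot be told apart on these data. Compound 3, `CCCCCCCCCCS(=O)(=O)/C=C/c1ccc(O)c(O)c1`, has not yet been measured in this assay. It differs from compound 1 in one place: hydrogen in place of ethyl on a saturated chain carbon, ten or more bonds along the chain from a sulfonyl sulfur. Within the data shown here, no measured pair shows this change, so there is no step to lean on. The two measured compounds, with their different sulfonyl substituents, sit within the scatter of each other, and a step no larger than the scatter is expected for compound 3 in this assay, in no particular direction. The estimate for compound 3 is 8000 nM, with a range from 4000 nM to 16000 nM. The expected step is a 1.1-fold lower number from compound 1 to compound 3 (0.03 log units; within the scatter).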

Compound 3, half-maximal effective concentration: 6800 nM
Compound 3: middle estimate off by 1.2-fold (0.07 log units), on the high side, within the range that was stated.
By their numbers in this assay, from the lowest: compounds 3, 2 and 1 (each within the scatter of the next).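

In this assay, among these compounds, the step of a 1.3-fold lower number from compound 1 to compound 3 (0.10 log units; within the scatter) gives the first direct reading of this change, hydrogen in place of ethyl on a saturated chain carbon, ten or more bonds along the chain from a sulfonyl sulfur. On this evidence, removing ethyl at this place leaves compound 1 and compound 3 indistinguishable, so this outer part of the chain can be altered to this extent without a measurable difference in this assay. Nothing available explains this result or bears on it.

The compounds shown leave open whether a longer chain, or a chain ending in an amine or a carboxylic acid, would give a step beyond the scatter. They also leave open whether a much shorter chain, such as butyl, would still match compound 1.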